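The source may hold more compounds than are shown below. What is called first, only, known or untested is meant among the compounds shown, and "the series" means these compounds.

Compound 1 `COC(=O)c1ccc(-c2cnc(C(=O)CCc3ccc(-c4ccccc4)cc3)o2)nc1` in an assay for inhibition of Fatty-acid amide hydrolase 1 (Rattus norvegicus) (on this read-out higher numbers stand for weaker inhibition and lower numbers for stronger inhibition), gives 2.2 nM. Among the three measured compounds it holds the second highest number; its nearest neighbour is compound 2 `COC(=O)c1cnc(C(=O)CCc2ccc(Oc3ccccc3)cc2)o1`, which in this assay gives 1.7 nM, and the two lie within the scatter of each other. Compound 3 `COC(=O)c1ccc(-c2cnc(C(=O)CCc3ccc(Oc4ccccc4)cc3)o2)nc1` in this assay gives 54 nM, the value furthest from compound 1. The two measured steps are a 25-fold higher number from compound 1 to compound 3 (1.39 log units; beyond the scatter) and a 32-fold higher number from compound 2 to compound 3 (1.50 log units; beyond the scatter), both large and both beyond the scatter.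

The step now followed leads from compound 1 to compound 4 `COC(=O)c1cccc(-c2cnc(C(=O)CCc3ccc(-c4ccccc4)cc3)o2)n1`, and the change is 6-(methoxycarbonyl)pyridin-2-yl in place of 5-(methoxycarbonyl)pyridin-2-yl on an aromatic carbon. Neither measured step bears on this change: one exchanges phenoxy for phenyl, the other replaces methoxycarbonyl with the whole 5-(methoxycarbonyl)pyridin-2-yl group. For the measured compounds named here, nothing among the measured compounds shows what happens when the methoxycarbonyl is moved within a pyridin-2-yl group while the rest of the molecule stays unchanged. The shared core and every other part of compound 1 remain in compound 4. Going by the values given here, with no measured step of this kind, the expectation is a step within the scatter, a 1.4-fold higher number from compound 1 to compound 4 (0.13 log units; within the scatter). Compound 4 is therefore estimated to give 3 nM, with a range from 0.8 nM to 15 nM.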

Compound 4, inhibition constant: 1.2 nM
For compound 4 the middle estimate is 2.5-fold (0.40 log units) above the measured one, within the range that was stated.
By their numbers in this assay, from the lowest: compounds 4, 2 and 1 (each within the scatter of the next); then compound 3.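

In this assay, exchanging 5-(methoxycarbonyl)pyridin-2-yl for 6-(methoxycarbonyl)pyridin-2-yl on the aromatic carbon next to the ring oxygen gives a 1.8-fold lower number from compound 1 to compound 4 (0.26 log units; within the scatter) and so leaves the two compounds within the scatter of each other. The earlier steps shown here showed only what followed from exchanging phenyl for phenoxy or from replacing methoxycarbonyl with a whole pyridinyl group, whereas this pair has the same atoms joined differently, and it shows that, with the rest of compound 1 kept, the two placements of the methoxycarbonyl on the pyridin-2-yl group cannot be told apart in this read-out. No measurement available here bears on why the two placements read alike.

It remains open whether phenoxy in place of phenyl would bring the same large step with 6-(methoxycarbonyl)pyridin-2-yl as it does with 5-(methoxycarbonyl)pyridin-2-yl, since the compounds shown hold phenoxy only with the latter. Also open, from the compounds shown here alone, is how the inhibition would respond to a carboxylic acid or an amide in place of the methoxycarbonyl on this pyridin-2-yl group.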